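Replacing 2,2,2-trifluoro-1-hydroxyethyl with acetoxymethyl in compound 2

The source may report more compounds than this note shows. Statements on the series, on what has been measured and on what is new or still open speak of the compounds shown alone.

Among the measured compounds shown here, in an ADME assay on S9 fraction from liver (Rattus norvegicus) for metabolic stability, read by LC-MS, using NADPH, with a stated time of 60 min, tested at 10 uM (a higher number here means that more of the compound is left, a lower number that less of the compound is left), compound 1 `N#CC1(c2cc(CC(O)C3CC3)cc(-c3ccnc4[nH]nc(C(F)(F)F)c34)c2)CC1` gives 0%, while compound 2 `N#CC1(c2cc(CC(O)C(F)(F)F)cc(-c3ccnc4[nH]nc(C(F)(F)F)c34)c2)CC1` gives 71%, the higher of the two numbers so far. For the measured compounds named here, the only measured step is a number 71 percentage points higher from compound 1 to compound 2 (beyond the scatter), a large one, with trifluoromethyl in place of cyclopropyl. Compound 3 `CC(=O)OCCc1cc(-c2ccnc3[nH]nc(C(F)(F)F)c23)cc(C2(C#N)CC2)c1` differs from compound 2 in one place: acetoxymethyl in place of 2,2,2-trifluoro-1-hydroxyethyl on a saturated chain carbon bound to an aromatic carbon. Put simply, acetoxymethyl stands in place of 2,2,2-trifluoro-1-hydroxyethyl on a saturated chain carbon bound to an aromatic carbon. The measured step is not the same swap, but it bears on this one, since compound 3 also has no trifluoromethyl on the chain and compound 1, which lacks it too, gives 0%. Going by the values given here, no measured compound carries acetoxymethyl, and two compounds are a thin basis, so the expectation is loose. A large fall in this assay is expected, beyond the scatter and perhaps not quite as large as the measured step. The estimated change is a number 56 percentage points lower from compound 2 to compound 3 (beyond the scatter). For compound 3 the expected value is 15%, with an estimated range from 0% to 45%.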

Compound 3, percent of the compound remaining: 5%
Compound 3: the middle estimate sits 10 percentage points above what was measured, within the range that was stated.
By their numbers in this assay, from the lowest: compounds 1 and 3 (each within the scatter of the next); then compound 2.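

In this assay the swap at this place, on a saturated chain carbon bound to an aromatic carbon, gives a number 66 percentage points lower from compound 2 to compound 3 (beyond the scatter) and so acetoxymethyl does not keep the high number seen with 2,2,2-trifluoro-1-hydroxyethyl. Against the cyclopropyl-bearing compound the reading is a number 5 percentage points higher from compound 1 to compound 3 (within the scatter) and so acetoxymethyl and cyclopropyl(hydroxy)methyl cannot be told apart here, even though one is an ester and the other a free alcohol. Among the compounds shown here, of these three compounds, only the one with 2,2,2-trifluoro-1-hydroxyethyl stands high, and two quite different groups now sit together at the low end, though no measurement offered here explains the result.

Compound 3 loses the trifluoromethyl and the free hydroxyl in a single change, so the compounds shown do not separate what each of the two contributes. Going by these compounds, it also remains open whether a plain 2-hydroxyethyl, a methyl ether, an amide or a carboxylic acid in this place would read closer to compound 2 or closer to compound 1.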